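Allyl-to-methoxyethyl swap on the amide nitrogen of compound 1

The source may hold more compounds than are shown below. What is called first, only, known or untested is meant among the compounds shown, and "the series" means these compounds.

Compound 1 `C=CCN(Cc1cccs1)C(=O)COc1ccc(C)cc1` holds the lowest number of the two measured in an assay on HEK293 cells for agonist activity at transient receptor potential cation channel subfamily M member 8 (Homo sapiens), read by fluorescence and calcium flux, with a stated time of 15 min; a higher number here means that more compound is needed for the effect, a lower number that less compound is needed; compound 1 gives 20 nM, while compound 2 `CCN(Cc1ccccc1)C(=O)COc1ccc(C)cc1` gives 1880 nM, a gap beyond the scatter. Compound 3 `COCCN(Cc1cccs1)C(=O)COc1ccc(C)cc1` has not yet been measured. Its difference from compound 1: methoxymethyl in place of vinyl on a saturated chain carbon bound to an amide-type nitrogen. Among the measured compounds shown here, no step between measured compounds touches this position, so the direction can only be guessed; a modest rise in the number is expected, with a 3.0-fold higher number from compound 1 to compound 3 (0.48 log units; beyond the scatter) as the estimated step. For compound 3 the expected value in this assay is 60 nM, with a range from 15 nM to 300 nM.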

Compound 3, half-maximal effective concentration: 400 nM
Estimate against measurement, compound 3: 6.7-fold (0.82 log units) below; the whole stated range lies below it.
By their numbers in this assay, from the lowest: compound 1; then compound 3; then compound 2.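

The first step read at this place shows that the number responds strongly to the group on a saturated chain carbon bound to an amide-type nitrogen. In this assay, methoxymethyl in place of vinyl, or allyl to 2-methoxyethyl, gives a 20-fold higher number from compound 1 to compound 3 (1.30 log units; beyond the scatter), with the rest of compound 1 unchanged. No measurement at hand explains the size of this step.

The compounds shown do not separate the removal of the double bond from the arrival of the ether oxygen. As far as these compounds go, a saturated propyl chain at this place would bear on that, while an amine or a longer chain remains open.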